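Ring-nitrogen substituent change from compound 3 to compound 4

A few compounds are considered here, and "the series" means these few. Any claim that something is new, unique, unknown or untested is made for them only; others in the source may bear on it.

Measured compounds:
compound 1 `CCCCCC(=O)c1ccc(OCCCN2CCN(C(=O)OC)CC2)cc1`, 12000 nM
compound 2 `CCCCCC(=O)c1ccc(OCCCN2CCN(C(=O)C(C)C)CC2)cc1`, 29500 nM
compound 3 `CCCCCC(=O)c1ccc(OCCCN2CCN(C(=O)C3CCC3)CC2)cc1`, 10200 nM

In an assay on isolated protein for binding affinity to histamine H2 receptor (Homo sapiens) (a lower number here means a stronger inhibitor, a higher number a weaker inhibitor), compound 3 stands at the low end of the three numbers; compound 1 lies within the scatter of it, as a 1.2-fold lower number from compound 1 to compound 3 (0.07 log units; within the scatter) shows, while a 2.9-fold lower number from compound 2 to compound 3 (0.46 log units; beyond the scatter) is a modest step beyond it. Compound 4 `CCCCCC(=O)c1ccc(OCCCN2CCN(CCCC)CC2)cc1` differs from compound 3 by butyl in place of cyclobutylcarbonyl on an amine nitrogen in a ring. Within the data shown here, the measured steps, a 2.5-fold higher number from compound 1 to compound 2 (0.39 log units; beyond the scatter) and a 2.9-fold lower number from compound 2 to compound 3 (0.46 log units; beyond the scatter), exchange only the group on the carbonyl carbon; no measured step removes the carbonyl itself, so none bears directly on this change. All steps seen so far are modest or within the scatter, which gives no ground to expect a large move in this assay. Compound 4 is therefore estimated at 8000 nM (range 2000 nM to 40000 nM), a step of a 1.3-fold lower number from compound 3 to compound 4 (0.11 log units; within the scatter) that is expected to stay within the scatter.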

Compound 4, inhibition constant: 7590 nM
Estimate against measurement, compound 4: 1.1-fold (0.02 log units) above, within the range that was stated.
By their numbers in this assay, from the lowest: compounds 4, 3 and 1 (each within the scatter of the next); then compound 2.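

In this assay, among these compounds, the carbonyl on the amine nitrogen in a ring is exchanged outright for the first time: a 1.3-fold lower number from compound 3 to compound 4 (0.13 log units; within the scatter) and a 1.6-fold lower number from compound 1 to compound 4 (0.20 log units; within the scatter) show that a butyl group without a carbonyl keeps the number within the scatter of these two compounds. Only isopropylcarbonyl separates from butyl, with a 3.9-fold lower number from compound 2 to compound 4 (0.59 log units; beyond the scatter) as a modest step. No supporting data bear on this result. Open, on these data alone, is how a longer chain, a benzyl group or a bare hydrogen on this nitrogen would read in this assay as well as whether any group here can give a large step.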